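A few compounds are considered here, and "the series" means these few. Any claim that something is new, unique, unknown or untested is made for them only; others in the source may bear on it.

Two measured compounds open the account. Compound 1, `CCCC(=O)OCSc1ccc(OC)cc1C(=O)NCCC(N)=O`, is assessed in an ADME assay on CEM-SS cells (Homo sapiens) for cytotoxicity, read by XTT assay, with a stated time of 6 days (on this read-out lower numbers stand for higher toxicity in this test and higher numbers for lower toxicity in this test), and in this assay compound 1 gives > 100 uM, which is a limit of the assay rather than a number. Compound 2, `CCCC(=O)OCSc1ccccc1C(=O)NCCCCC(N)=O`, gives 51.7 uM in this assay, and it is the only numeric value among the two results shown, the other result being (the limit of > 100 uM in this assay, at which 1 of the 2 values shown sits). Compound 3, `CCCC(=O)OCSc1ccccc1C(=O)NCC(=O)N(C)C`, has not been measured in this assay. Set against compound 2, compound 3 carries dimethylcarbamoyl in place of 3-carbamoylpropyl on a saturated chain carbon bound to an amide-type nitrogen. No step between measured compounds is shown, so the effect of this change can only be guessed. The expected step from compound 2 to compound 3, a 1.4-fold higher number from compound 2 to compound 3 (0.13 log units; within the scatter), is small and within the scatter of this assay. Compound 3 is therefore expected to give 70 uM in this assay, in a range from 30 uM to 160 uM.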

Compound 3, half-maximal toxic concentration: 38.3 uM
Compound 3: middle estimate off by 1.8-fold (0.26 log units), on the high side; low and high end bracket the measured number.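

In this assay, among these compounds, this position now has a step that can be read, a 1.3-fold lower number from compound 2 to compound 3 (0.13 log units; within the scatter), the first between two compounds that differ in one place. Dimethylcarbamoyl in place of 3-carbamoylpropyl on a saturated chain carbon bound to an amide-type nitrogen therefore leaves the read-out without a change that can be told apart from the scatter, although the group that leaves carries 1 hydrogen-bond donor and the group that enters carries 0. Among the compounds shown here, compound 1 gives a limit rather than a number, and no step to it can be read: the limit of > 100 uM in this assay, at which 1 of the 3 values shown sits.

The compounds shown leave open whether any group at this place moves the number beyond the scatter. An amine or a carboxylic acid at the end of the chain would test that, as would a longer chain.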